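The source may report more compounds than this note shows. Statements on the series, on what has been measured and on what is new or still open speak of the compounds shown alone.

Compound 1 `COc1ccc(-c2cn3ccnc3c(-c3ccc4ncn(C5CCCCC5)c4c3)n2)cc1`: 92.5%
Compound 2 `Brc1ccc(-c2cn3ccnc3c(-c3ccc4ncn(C5CCCCC5)c4c3)n2)cc1`: 20.9%

For the measured compounds named here, in a functional assay on HT-29 cells (Homo sapiens) for inhibition, read by sulforhodamine B assay, with a stated time of 48 h, tested at 10 uM (on this read-out higher numbers stand for more inhibition at the one concentration tested (going by the name of the read-out) and lower numbers for less inhibition), compound 1 gives 92.5%, whereas compound 2 gives 20.9%, the lowest of the two numbers; the only measured step, a number 71.6 percentage points lower from compound 1 to compound 2 (beyond the scatter), separates them. Compound 3 `c1csc(-c2cn3ccnc3c(-c3ccc4ncn(C5CCCCC5)c4c3)n2)c1` differs from compound 2 by thiophen-2-yl in place of 4-bromophenyl on an aromatic carbon. Going by the values given here, no measured step exchanges the whole ring, so bromo in place of methoxy on an aromatic carbon is only a loose guide: it shows that exchanging what sits there changes this assay strongly. The step expected is a number 29.1 percentage points higher from compound 2 to compound 3 (beyond the scatter), with wide uncertainty. For compound 3 the estimate is 50%, ranging from 12% to 88%.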

Compound 3, a percentage reported as inhibition, at one concentration (the size of the read-out at that concentration, not a potency): 0.09%
Estimate against measurement, compound 3: 49.9 percentage points above; measured number below the stated range.
By their numbers in this assay, from the lowest: compound 3; then compound 2; then compound 1.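

In this assay thiophen-2-yl at this position gives a number a number 20.8 percentage points lower from compound 2 to compound 3 (beyond the scatter) and a number 92.4 percentage points lower from compound 1 to compound 3 (beyond the scatter), so the five-membered ring with sulfur does not restore the inhibition lost with the 4-bromophenyl group. Of the three groups at this position, only 4-methoxyphenyl gives a high number, and compound 3 stands lowest with both of its steps beyond the scatter. Nothing measured here accounts for these differences.

The compounds shown leave open whether a plain phenyl ring or a 4-aminophenyl group would stay near compound 1. They also leave open whether a longer alkoxy chain such as ethoxy would hold that number.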